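A few compounds are considered here, and "the series" means these few. Any claim that something is new, unique, unknown or untested is made for them only; others in the source may bear on it.

Working notes on the series.

Compound 1 `N#CCC(=C(c1ccc(O)cc1)c1ccc(O)cc1)c1ccccc1`, compound 2 `N#CCC(=C(c1ccc(O)cc1)c1ccc(O)cc1)c1ccc(O)cc1` and compound 3 `N#CCC(=C(c1ccc(O)cc1)c1ccc(O)cc1)c1ccc(O)c(F)c1` share one core. In an assay on isolated protein for inhibition of Aromatase (Homo sapiens), read by fluorescence, using NADPH, with a stated time of 30 min, in the presence of a further agent that is not named here (a higher number here means a weaker inhibitor, a lower number a stronger inhibitor), compound 1 gives 12800 nM, compound 2 gives 15200 nM and compound 3 gives 17200 nM. Compound 3 sits within the scatter of both neighbours: a 1.3-fold higher number from compound 1 to compound 3 (0.13 log units; within the scatter) and a 1.1-fold higher number from compound 2 to compound 3 (0.05 log units; within the scatter). The third step, a 1.2-fold higher number from compound 1 to compound 2 (0.07 log units; within the scatter), is likewise within the scatter, so on the numbers shown no compound can be set apart from another.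

Compound 4 `N#CCC(=C(c1ccc(O)cc1)c1ccc(O)cc1)c1ccc(N)cc1` has not yet been measured in this assay. Its change from compound 3 is 4-aminophenyl in place of 3-fluoro-4-hydroxyphenyl on a double-bonded chain carbon bound to a double-bonded chain carbon and a saturated chain carbon. Among the measured compounds shown here, the steps that bear on it are a 1.1-fold higher number from compound 2 to compound 3 (0.05 log units; within the scatter), which adds the fluoro that now leaves, and a 1.2-fold higher number from compound 1 to compound 2 (0.07 log units; within the scatter), which adds the hydroxy that is now exchanged for amino; both sat within the scatter. The expectation for this assay is therefore a step of a 1.1-fold lower number from compound 3 to compound 4 (0.06 log units; within the scatter), that is, none beyond the scatter. Compound 4 is estimated at 15000 nM, with a range of 7000 nM to 32000 nM.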

Compound 4, half-maximal inhibitory concentration: 36.3 nM
Estimate against measurement, compound 4: 410-fold (2.62 log units) above; the whole stated range lies above it.
By their numbers in this assay, from the lowest: compound 4; then compounds 1, 2 and 3 (each within the scatter of the next).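

Among the compounds shown here, at this place, on a double-bonded chain carbon bound to a double-bonded chain carbon and a saturated chain carbon, the aromatic group has a far larger effect in this assay than the earlier compounds showed: amino in place of hydroxy gives a 420-fold lower number from compound 2 to compound 4 (2.62 log units; beyond the scatter), and amino in place of hydrogen gives a 350-fold lower number from compound 1 to compound 4 (2.55 log units; beyond the scatter), whereas hydroxy in place of hydrogen gave only a 1.2-fold higher number from compound 1 to compound 2 (0.07 log units; within the scatter). The exchange of 3-fluoro-4-hydroxyphenyl for 4-aminophenyl gives a 470-fold lower number from compound 3 to compound 4 (2.68 log units; beyond the scatter), so all three large steps end at the 4-aminophenyl compound, while the three groups it replaces stay within the scatter of one another. Nothing available here accounts for this change.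

The compounds shown leave open whether the amino group tolerates substitution, as a methylamino, dimethylamino or acetamido group would test. Also open, as far as these compounds go, is whether amino in place of hydroxy on the other two aromatic rings of the shared core would give a similar step.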